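A few compounds are considered here, and "the series" means these few. Any claim that something is new, unique, unknown or untested is made for them only; others in the source may bear on it.

Measured in a functional assay on MV4-11 cells (Homo sapiens) for inhibition, read by resazurin assay, with a stated time of 72 h; a lower number here means a stronger inhibitor of growth, a higher number a weaker inhibitor of growth:
- compound 1 `O=C1NCCC12CCN(c1c(Cl)cncc1-c1cc[nH]c1)CC2`: 1050 nM
- compound 2 `O=C1NCCC12CCN(c1c(Cl)cncc1-c1cn[nH]c1)CC2`: 8520 nM

Of these two, compound 2 has the higher number, so it is the weaker inhibitor of growth in this assay. The gap is an 8.1-fold higher number from compound 1 to compound 2 (0.91 log units; beyond the scatter).

Next is compound 3 `O=C1NCCC12CCN(c1c(Cl)cncc1-c1cnn(C(F)F)c1)CC2`, which carries difluoromethyl in place of hydrogen on an aromatic nitrogen.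

Going by the values given here, only one measured step is available, and it exchanges one five-membered ring for another rather than substituting a ring nitrogen. It therefore gives a rough scale for changes at this part of the molecule, but no direct guide to direction. The scale comes from an 8.1-fold higher number from compound 1 to compound 2 (0.91 log units; beyond the scatter). A change of similar or smaller size is expected here. With compound 2 at 8520 nM, a slight move towards a lower number is the tentative expectation, with a move the other way not excluded.

The expected change is a 1.3-fold lower number from compound 2 to compound 3 (0.12 log units; within the scatter). The estimate for compound 3 is 6500 nM, with an expected range from 2000 nM to 20000 nM.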

Compound 3, concentration for 50% growth inhibition: 6140 nM
For compound 3 the middle estimate is 1.1-fold (0.02 log units) above the measured one, within the range that was stated.
By their numbers in this assay, from the lowest: compound 1; then compounds 3 and 2 (each within the scatter of the next).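

In this assay, the aromatic nitrogen of the pyrazole ring tolerates difluoromethyl in place of hydrogen: a 1.4-fold lower number from compound 2 to compound 3 (0.14 log units; within the scatter). Compound 2 and compound 3 therefore cannot be separated in this assay, so the hydrogen on that nitrogen is not required to hold the number at this level, although this rests on a single substituent. The step from the pyrrole is still beyond the scatter with the new group in place, at a 5.8-fold higher number from compound 1 to compound 3 (0.77 log units; beyond the scatter), so difluoromethyl does not bring the pyrazole series level with compound 1, and no measurement at hand accounts for either step.

On these data alone, it remains open whether methyl, or a longer chain ending in an amine or a carboxylic acid, on the same aromatic nitrogen would stay level with compound 2 and compound 3 in this assay or move clearly away from them. As far as these compounds go, it is also open whether difluoromethyl on the ring nitrogen of the 1H-pyrrol-3-yl group of compound 1 would likewise leave the number within the scatter, which would show whether this tolerance carries over to the stronger ring.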